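Second 3-chlorophenyl sulfonamide tested on lin-28 homolog A

The compounds below may be only part of what the source reports. "The series", "measured", "known", "first", "only" and "open" are said of these compounds alone.

Compound 1 `COc1ccc(S(=O)(=O)Nc2ccccc2NS(=O)(=O)c2ccc(F)cc2)cc1` gives 17200 nM in an assay for binding affinity to protein lin-28 homolog A (Mus musculus), with a stated time of 1 h; on this read-out lower numbers stand for stronger inhibition and higher numbers for weaker inhibition.
Compound 2 `O=S(=O)(Nc1ccccc1NS(=O)(=O)c1cccc(Cl)c1)c1ccc(F)cc1` gives 10800 nM in this assay.
Compound 3 `O=S(=O)(Nc1ccccc1NS(=O)(=O)c1cccc(Br)c1)c1ccc(F)cc1` gives 16200 nM in this assay.

Among the three measured compounds, compound 2 has the lowest number, but its steps to compound 3 and to compound 1 both lie within the scatter, so the three cannot be ranked. Compound 4 `O=S(=O)(Nc1ccccc1NS(=O)(=O)c1cccc(Cl)c1)c1cccc(Cl)c1` has not yet been measured. It differs from compound 2 by 3-chlorophenyl in place of 4-fluorophenyl on a sulfonyl sulfur. Among the measured compounds shown here, the only steps that bear on this change are the exchanges on the other sulfonyl sulfur: a 1.6-fold lower number from compound 1 to compound 2 (0.20 log units; within the scatter) and a 1.1-fold lower number from compound 1 to compound 3 (0.03 log units; within the scatter), together with a 1.5-fold higher number from compound 2 to compound 3 (0.18 log units; within the scatter). None of them moved the number beyond the scatter, and every one involved a halogenated or methoxylated phenyl on a sulfonyl sulfur of the shared core. Compound 4 is therefore expected to sit close to compound 2, with any step a 1.2-fold lower number from compound 2 to compound 4 (0.08 log units; within the scatter) likely within the scatter. The estimate for compound 4 in this assay is 9000 nM, with a range from 4000 nM to 20000 nM.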

Compound 4, half-maximal inhibitory concentration: 5700 nM
The estimate for compound 4 lay 1.6-fold (0.20 log units) above the measured number; the range from low to high includes it.
By their numbers in this assay, from the lowest: compounds 4, 2, 3 and 1 (each within the scatter of the next, the first and the last beyond it).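

In this assay, the step of a 1.9-fold lower number from compound 2 to compound 4 (0.28 log units; within the scatter) lies within the scatter, and it is the first exchange shown at the sulfonyl sulfur that carries 4-fluorophenyl in compound 1, compound 2 and compound 3. Compound 4 has 3-chlorophenyl on both sulfonyl sulfurs, so the result shows that the shared core can lose 4-fluorophenyl altogether and stay within the scatter of compound 2. Nothing available here accounts for the step.

All the groups on the sulfonyl sulfurs so far are phenyl rings bearing a halogen or methoxy, and no single exchange has yet moved the number beyond the scatter. On these data alone, it remains open whether a phenyl ring bearing an amine or a carboxylic acid, or a longer alkyl chain in place of the ring, would do so.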